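Methyl to Benzyl on the Shared Core: An Estimate

The source may report more compounds than this note shows. Statements on the series, on what has been measured and on what is new or still open speak of the compounds shown alone.

Measured so far:
compound 1 `Cn1c([S-])n[n+]2c(N)c(C#N)c(-c3ccc(N4CCCCC4)cc3)c(C#N)c12`: 51.1%
compound 2 `CN1CCN(c2ccc(-c3c(C#N)c(N)[n+]4nc([S-])n(C)c4c3C#N)cc2)CC1`: 36.6%

In a functional assay on the whole organism (strain Wister albino) for inhibition, with Rattus norvegicus as the target, read by paw edema, with stated times of 1 h and 4 h, at a dose of 50 mg/kg by the intraperitoneal route (a higher number here means more inhibition at the dose given (going by the name of the read-out), a lower number less inhibition), compound 1 gives 51.1%, the higher of the two numbers shown. Compound 2 gives 36.6%, and the step of a number 14.5 percentage points lower from compound 1 to compound 2 (beyond the scatter) goes with 4-methylpiperazin-1-yl in place of piperidin-1-yl on an aromatic carbon. Compound 3 `N#Cc1c(-c2ccc(N3CCCCC3)cc2)c(C#N)c2n(Cc3ccccc3)c([S-])n[n+]2c1N` differs from compound 1 by phenyl in place of hydrogen on a saturated chain carbon bound to an aromatic nitrogen, that is, methyl to benzyl. Among the compounds with values here, no measured step touches this part of the shared core, so the one measured step offers no direct guide, and the estimate leans on compound 1 alone. Compound 3 is therefore expected near 48%, between 28% and 68%, meaning an expected step of a number 3.1 percentage points lower from compound 1 to compound 3 (within the scatter) within the scatter.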

Compound 3, a percentage reported as inhibition, in the whole organism at one dose (the size of the read-out at that dose, not a potency): 67.4%
Beside the measured number, compound 3's estimate is 19.4 percentage points below it; the measured number falls inside the stated range.
By their numbers in this assay, from the lowest: compound 2; then compound 1; then compound 3.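

In this assay methyl to benzyl gives a number 16.3 percentage points higher from compound 1 to compound 3 (beyond the scatter) and so shows that this place, on a saturated chain carbon bound to an aromatic nitrogen, responds to change. Phenyl added here raises the number, whereas the earlier step, on an aromatic carbon, lowered it. Nothing measured here explains the rise.

From the compounds shown here alone, it remains open whether ethyl or cyclohexylmethyl in place of methyl would match benzyl. Going by these compounds, it is also open whether benzyl would bring a similar rise alongside the 4-methylpiperazin-1-yl group of compound 2.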